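Benzylamide series: adding trifluoromethyl to the chloro compound

The source may report more compounds than this note shows. Statements on the series, on what has been measured and on what is new or still open speak of the compounds shown alone.

Measured so far:
compound 1, `CCN1C(=O)CC[C@H]1C(=O)NCc1ccccc1Cl`: 631 nM
compound 2, `CCN1C(=O)CC[C@H]1C(=O)NCc1ccccc1C(F)(F)F`: 631 nM

In an assay on isolated protein for inhibition of P2X purinoceptor 7 (Homo sapiens) (on this read-out lower numbers stand for stronger inhibition and higher numbers for weaker inhibition), compound 1 gives 631 nM. Compound 2 gives 631 nM. The step of no change at the digits printed from compound 1 to compound 2 (within the scatter) lies within the scatter, so compound 1 stands level with compound 2 and neither can be ranked against the other.

Compound 3, `CCN1C(=O)CC[C@H]1C(=O)NCc1cccc(C(F)(F)F)c1Cl`, differs from compound 1 by trifluoromethyl in place of hydrogen on an aromatic carbon. Among the measured compounds shown here, the only measured step that bears on this, no change at the digits printed from compound 1 to compound 2 (within the scatter), exchanges chloro for trifluoromethyl rather than adding a trifluoromethyl beside a retained chloro, so it covers the new change only in part; it does show that a trifluoromethyl on this ring leaves the series at the level of compound 1. For the measured compounds named here, no measured step reports two groups on the ring together.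

Compound 3 is therefore expected to stay close to compound 1, with an expected step of a 1.1-fold lower number from compound 1 to compound 3 (0.02 log units; within the scatter). The estimate for compound 3 in this assay is 600 nM, with an expected range from 200 nM to 2000 nM.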

Compound 3, half-maximal inhibitory concentration: 1.59 nM
Beside the measured number, compound 3's estimate is 380-fold (2.58 log units) above it, and the stated range ends above it.
By their numbers in this assay, from the lowest: compound 3; then compounds 1 and 2 (each within the scatter of the next).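

In this assay, among the compounds shown here, trifluoromethyl in place of hydrogen on an aromatic carbon, ortho to a chloro group, gives a 400-fold lower number from compound 1 to compound 3 (2.60 log units; beyond the scatter) and is the first change to move the read-out beyond the scatter. The exchange of chloro for trifluoromethyl gave no change at the digits printed from compound 1 to compound 2 (within the scatter) and so did not predict this: adding trifluoromethyl while the chloro group stays has a very different outcome from replacing the chloro group. No measurement shown here accounts for the size of this step.

Still open, from the compounds shown here alone, is whether the gain depends on the retained chloro group. Going by these compounds, it is equally open whether a nitrile, a methoxy group or an amine on this same aromatic carbon would give a step of similar size.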